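From cyclopropylamino to allylamino at the assay limit

The compounds below may be only part of what the source reports. "The series", "measured", "known", "first", "only" and "open" are said of these compounds alone.

Measured so far in a functional assay (aorta) with Rattus norvegicus as the target; on this read-out lower numbers stand for an effect already at smaller amounts and higher numbers for an effect only at larger amounts of compound:
Compound 1 `CC(C)NC1=NS(=O)(=O)c2cc(Cl)ccc2N1`: 36.3 uM
Compound 2 `CCC(C)NC1=NS(=O)(=O)c2cc(F)ccc2N1`: 39.2 uM
Compound 3 `O=S1(=O)NC(NC2CC2)=Nc2ccc(F)cc21`: > 300 uM (a limit)

Compound 3 has no number in this assay, and its > 300 uM is a limit of the assay. That reading is the limit of > 300 uM in this assay, at which 1 of the 3 values shown sits.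

Compound 4 `C=CCNC1=Nc2ccc(F)cc2S(=O)(=O)N1` has not yet been measured. It differs from compound 3 by having allyl in place of cyclopropyl on an amine nitrogen. Going by the values given here, no two measured compounds differ in only one place, so the expectation rests on thin ground. Compound 1 gives 36.3 uM and compound 2 gives 39.2 uM, both with an open chain on that nitrogen. Compound 4 also has an open chain there, so a move towards lower numbers, beyond the scatter, is expected, although a limit remains possible. The expected size of the change is an at least 3.0-fold lower number from compound 3 to compound 4 (0.47 log units; beyond the scatter). For compound 4 the estimated value is 100 uM, with an expected range of 35 uM to 300 uM.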

Compound 4, concentration for half-maximal effect: > 300 uM
Compound 4: only a limit was reported; the forecaster's own chance of this, stated with the estimate: 25%; middle value at least 3.0-fold (0.47 log units) away from the limit.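

In this assay compound 4, like compound 3, stands at a limit of the assay and not at a number, so no step can be read between the two: the limit of > 300 uM in this assay, at which 2 of the 4 values shown sit.

The compounds shown leave open whether allyl and cyclopropyl on an amine nitrogen differ at all on this read-out.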